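The source may hold more compounds than are shown below. What is called first, only, known or untested is meant among the compounds shown, and "the series" means these compounds.

Measured compounds:
- compound 1, `O=C(O)c1ccc(COc2ccc(CNC(=O)[C@@H]3CCC(=O)N3Cc3ccccc3)cc2)cc1`: 4500 nM
- compound 2, `O=C(O)c1ccc(COc2ccc(CNC(=O)[C@H]3CCC(=O)N3Cc3ccccc3)cc2)cc1`: > 5000 nM, which is a limit of the assay and not a number

Among the measured compounds shown here, compound 1 is the only compound here with an actual number in an assay on HEK293 cells for inhibition of Ataxin-2 (Mus musculus), read by fluorescence and Amplex Red; a higher number here means a weaker inhibitor, a lower number a stronger inhibitor. Compound 2 gives only a limit in this assay. For the measured compounds named here, the one measured step, an at least 1.1-fold higher number from compound 1 to compound 2 (0.04 log units; that floor lies within the scatter), concerns just the configuration at one ring carbon, as the fact that compounds 1 and 2 differ only in the configuration as drawn shows, and its floor comes from the limit of > 5000 nM in this assay, at which 1 of the 2 values shown sits.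

Compound 3, `O=C(NCc1ccc(OCc2ccc(B(O)O)cc2)cc1)[C@@H]1CCC(=O)N1Cc1ccccc1`, differs from compound 1 in another way: a group of 3 heavy atoms (1 boron, 2 oxygen; no ring) in place of a group of 3 heavy atoms (1 carbon, 2 oxygen; no ring), on an aromatic carbon. Going by the values given here, no measured step touches such an exchange, so the data give no basis for expecting a shift beyond the scatter in either direction. Compound 3 is therefore estimated to give about 4500 nM in this assay, within 1500 nM to 15000 nM, meaning an expected step of no change at the digits printed from compound 1 to compound 3 (within the scatter).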

Compound 3, half-maximal inhibitory concentration: 35 nM
Estimate against measurement, compound 3: 130-fold (2.11 log units) above; measured number outside the range, below it.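

Swapping the carboxy group for the group of 3 heavy atoms (1 boron, 2 oxygen) gives a 130-fold lower number from compound 1 to compound 3 (2.11 log units; beyond the scatter) in this assay. This position, on an aromatic carbon para to a large group, therefore strongly affects the read-out, something compounds 1 and 2 could not show, as they differ only at a saturated ring carbon. The measurements show the size of this step but not its cause, and nothing given here explains it.

As far as these compounds go, it remains open whether other groups at this position, such as an amine, a nitrile or a longer chain ending in a carboxylic acid, would lower the number in the same way. Among the compounds shown here, it is also open how the boron-containing group behaves when combined with the other ring-carbon configuration, the one drawn in compound 2.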